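This account rests on a few compounds, and the source may have more. Where it says the series, first, only, none or still open, it means among the compounds named here.

Working notes on the series.

Compound 1 `O=S(=O)(/C=C/c1ccc(F)cc1)Cc1ccc(Nc2ncnc3ccccc23)cc1` and compound 2 `O=S(=O)(/C=C/c1ccc(Cl)cc1Cl)Cc1ccc(Nc2ncnc3ccccc23)cc1` share one core; compound 3 `COc1cc2ncnc(Nc3ccc(CS(=O)(=O)/C=C/c4ccc(Cl)cc4Cl)cc3)c2cc1OC` carries a different core. In a functional assay on PC-3 cells (Homo sapiens) (a higher number here means a weaker inhibitor of growth, a lower number a stronger inhibitor of growth), compound 1 gives 1000 nM, compound 2 gives 19000 nM and compound 3 gives 5000 nM. Between compound 2 and compound 1 the change is 4-fluorophenyl in place of 2,4-dichlorophenyl on a double-bonded chain carbon bound to a double-bonded chain carbon, and it gives a 19-fold lower number from compound 2 to compound 1 (1.28 log units; beyond the scatter). Among the measured compounds shown here, the difference between the core of compound 2 and the core of compound 3 is not broken down here; their two values show only that compound 3 has the lower number.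

Compound 4 `COc1cc2ncnc(Nc3ccc(CS(=O)(=O)/C=C/c4ccc(F)cc4)cc3)c2cc1OC` is not yet measured in this assay. From compound 3 it carries the change (4-fluorophenyl in place of 2,4-dichlorophenyl on a double-bonded chain carbon bound to a double-bonded chain carbon), the same change as from compound 2 to compound 1, on the core of compound 3. The expectation is that compound 4 follows the direction seen in a 19-fold lower number from compound 2 to compound 1 (1.28 log units; beyond the scatter), with a step of about the same size, estimated as a 17-fold lower number from compound 3 to compound 4 (1.22 log units; beyond the scatter). From the compounds shown here alone, whether the core of compound 3 carries the change equally is untested, so the range is kept wide. For compound 4 the estimated value is 300 nM, expected between 100 nM and 1200 nM.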

Compound 4, concentration for 50% growth inhibition: > 100000 nM
Compound 4: a limit, no number; the forecaster's own chance of this, stated with the estimate: 2%; at least 330-fold (2.52 log units) between middle value and limit.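

Compound 4 gives > 100000 nM in this assay, which is a limit of the assay and not a number. Putting 4-fluorophenyl in place of 2,4-dichlorophenyl on the core of compound 3 gives an at least 20-fold higher number from compound 3 to compound 4 (1.30 log units; beyond the scatter), so the change does not carry over, and its direction reverses between the two cores: the same change on two cores in this assay, a 19-fold lower number (1.28 log units; beyond the scatter) from compound 2 to compound 1 and an at least 20-fold higher number (1.30 log units; beyond the scatter) from compound 3 to compound 4, at least 380-fold (2.57 log units) apart, beyond the scatter of two such steps. This shows that the outcome of the change depends on the core for these two pairs; it does not show why, how far the step extends past the limit, or that a general rule holds across the series.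

Open, from the compounds shown here alone, is whether the reversal is confined to 4-fluorophenyl and 2,4-dichlorophenyl or also appears with another group on the phenyl ring, such as a methoxy group or a nitrile. Also open, going by these compounds, is whether a core carrying a single methoxy group would follow compound 1 and compound 2 or compound 3 and compound 4.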